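A smaller group on the ring nitrogen in compound 4

This account rests on a few compounds, and the source may have more. Where it says the series, first, only, none or still open, it means among the compounds named here.

In an in vitro ADME assay on microsomes (Mus musculus) for metabolic stability (a higher number here means that the compound lasts longer, a lower number that the compound disappears faster), compound 3 (`CNC(=O)Nc1ccc(-c2nc(N3CC4CCC(C3)O4)c3cnn(C4CCC5(CC4)OCCCO5)c3n2)cc1`) gives > 0.5 h, which is a limit and not a number. Compound 1 (`O=C(Nc1ccccc1)Nc1ccc(-c2nc(N3CC4CCC(C3)O4)c3cnn(C4CCC5(CC4)OCCO5)c3n2)cc1`) gives > 0.5 h, also a limit. Compound 2 (`CCNC(=O)Nc1ccc(-c2nc(N3CC4CCC(C3)O4)c3cnn(C4CCC5(CC4)OCCO5)c3n2)cc1`) gives a measured 0.45 h. The set therefore sits largely at the limit of > 0.5 h in this assay, at which 2 of the 3 values shown sit.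

Compound 4 (`CNC(=O)Nc1ccc(-c2nc(N3CC4CCC(C3)O4)c3cnn(C4CCC(OC)(OC)CC4)c3n2)cc1`) differs from compound 3 by a group of 10 heavy atoms (8 carbon, 2 oxygen; one six-membered non-aromatic ring of carbon only) in place of a group of 11 heavy atoms (9 carbon, 2 oxygen; one six-membered non-aromatic ring of carbon only, one six-membered non-aromatic ring with 2 hetero atoms), on an aromatic nitrogen.

Among the compounds with values here, the only measured step, an at least 1.1-fold lower number from compound 1 to compound 2 (0.04 log units; that floor lies within the scatter), lies elsewhere, on an amide-type nitrogen, and its floor lies within the scatter. Within the data shown here, no measured step changes the group on the aromatic nitrogen, so no shift beyond the scatter is expected. The expected step is an at least 1.1-fold lower number from compound 3 to compound 4 (0.04 log units; that floor lies within the scatter). The estimated half-life for compound 4 is 0.45 h, with an expected range of 0.2 h to 0.9 h.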

Compound 4, half-life: 0.25 h
Compound 4: the middle estimate sits 1.8-fold (0.26 log units) above what was measured, and the stated range covers the measured number.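

Within the data shown here, on the aromatic nitrogen, the group of 10 heavy atoms in place of the group of 11 heavy atoms gives the first step at this position in this assay: an at least 2.0-fold lower number from compound 3 to compound 4 (0.30 log units; that floor lies within the scatter). Compound 3 gives > 0.5 h, which is a limit and not a number. The true size of the step therefore stays unknown, and its floor alone does not clear the scatter, because the starting value sits at a limit: the limit of > 0.5 h in this assay, at which 2 of the 4 values shown sit.

Still open, from the compounds shown here alone, is how a carbon ring carrying an amine or a carboxylic acid on this aromatic nitrogen would behave in this assay.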